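Compound 2 and an untested analogue in a cell assay

A few compounds are considered here, and "the series" means these few. Any claim that something is new, unique, unknown or untested is made for them only; others in the source may bear on it.

Compound 1 `O=C(COc1ccc(C(=O)N2CC=C(c3c[nH]c4ccc(F)cc34)CC2)cc1)NO`: > 5000 nM
Compound 2 `O=C(COc1ccc(CN2CC=C(c3c[nH]c4cccc(F)c34)CC2)c(F)c1)NO`: 5560 nM
Compound 3 `Cc1[nH]c2cccc(F)c2c1C1=CCC(NCc2ccc(OCC(=O)NO)cc2F)CC1`: "nd" (no result reported)

Among the measured compounds shown here, in a functional assay on SW480 cells (Homo sapiens) for antiproliferative activity, with a stated time of 72 h (on this read-out lower numbers stand for stronger inhibition and higher numbers for weaker inhibition), compound 2 gives 5560 nM, the only single number among the three compounds. For compound 1 the value > 5000 nM is a limit of the assay rather than a number (the limit of > 5000 nM in this assay, at which 1 of the 3 values shown sits). For compound 3 the entry reads "nd" (no result reported), with no result reported. Compound 4 `Cc1[nH]c2ccccc2c1C1=CCN(Cc2ccc(OCC(=O)NO)cc2F)CC1` differs from compound 2 in one place: 2-methyl-1H-indol-3-yl in place of 4-fluoro-1H-indol-3-yl on a double-bonded ring carbon. For the measured compounds named here, no step between two measured compounds is available, so the data give no measured size for such a change. Compound 4 is therefore expected to land close to compound 2, with the estimated step from compound 2 to compound 4 being a 1.1-fold lower number from compound 2 to compound 4 (0.05 log units; within the scatter), none beyond the scatter. The estimate for compound 4 is 5000 nM, with an expected range from 1800 nM to 14000 nM.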

Compound 4, half-maximal inhibitory concentration: 1600 nM
For compound 4 the middle estimate is 3.1-fold (0.49 log units) above the measured one; the whole stated range lies above it.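

In this assay, 2-methyl-1H-indol-3-yl in place of 4-fluoro-1H-indol-3-yl on a double-bonded ring carbon gives a 3.5-fold lower number from compound 2 to compound 4 (0.54 log units; beyond the scatter), the first measured size of a single change in this set. The indole group alone thus moves the read-out beyond the scatter, with the rest of compound 2 unchanged. The data shown offer no explanation for this step.

This single change both removes the fluorine and adds the methyl, and the two contributions cannot be separated. Going by these compounds, it remains open how the plain 1H-indol-3-yl group, or an ethyl group or a chlorine on the indole, would read here.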